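Replacing the benzylsulfonyl group of compound 1

This account rests on a few compounds, and the source may have more. Where it says the series, first, only, none or still open, it means among the compounds named here.

For the measured compounds named here, in a functional assay on HUVEC cells (Homo sapiens) for inhibition (a lower number here means a stronger inhibitor, a higher number a weaker inhibitor), compound 1 (`CN(c1ccc(NS(=O)(=O)Cc2ccccc2)cc1)c1ccnc(Nc2cccc(CS(C)(=O)=O)c2)n1`) gives 350 nM, the highest of the three numbers measured so far. Compound 2 (`CN(c1ccc(NC(=O)Nc2cc(C(F)(F)F)ccc2F)cc1)c1ccnc(Nc2ccc(S(N)(=O)=O)cc2)n1`) gives 8 nM and compound 3 (`CN(c1ccc(NC(=O)Nc2ccc(OC(F)(F)F)cc2)cc1)c1ccnc(Nc2cccc(S(N)(=O)=O)c2)n1`) gives 5 nM. Both lie beyond the scatter from compound 1 and within the scatter of each other. Going by the values given here, each of these two carries an arylcarbamoyl group on the nitrogen where compound 1 has benzylsulfonyl, but each also differs from compound 1 elsewhere, so no measured pair isolates that change.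

Compound 4 (`CN(c1ccc(NC(=O)Nc2c(Cl)cccc2Cl)cc1)c1ccnc(Nc2cccc(CS(C)(=O)=O)c2)n1`) makes the change alone: (2,6-dichlorophenyl)carbamoyl in place of benzylsulfonyl on a nitrogen on an aromatic ring. The rest of compound 1 stays in place.

The expectation leans on compound 2 at 8 nM and compound 3 at 5 nM, yet neither shares the remainder of compound 4 or its 2,6-dichlorophenyl group, so only part of the gap is expected to carry over. A step of a 12-fold lower number from compound 1 to compound 4 (1.07 log units; beyond the scatter) is expected, toward stronger inhibition and beyond the scatter. For compound 4 the estimated value is 30 nM, with an expected range from 6 nM to 150 nM.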

Compound 4, half-maximal inhibitory concentration: 29 nM
Compound 4: the middle estimate sits 1.0-fold (0.01 log units) above what was measured, within the range that was stated.
By their numbers in this assay, from the lowest: compounds 3 and 2 (each within the scatter of the next); then compound 4; then compound 1.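

In this assay, for the compounds shown here, the step of a 12-fold lower number from compound 1 to compound 4 (1.08 log units; beyond the scatter) is the first measured effect of this change on its own, with the rest of compound 1 held in place. Compounds 2 and 3 had hinted at such a gap, but they differ from compound 1 in more than one place; this pair shows that the group on this nitrogen on an aromatic ring can, by itself, move the number beyond the scatter toward stronger inhibition. No measurement given here bears on why the exchange of benzylsulfonyl for (2,6-dichlorophenyl)carbamoyl has this effect, so the step stands as an observation without an explanation.

Going by these compounds alone, the single pair does not separate the contribution of the carbonyl-bearing link from that of the two chlorine atoms: a phenylcarbamoyl group without chlorine, or a benzylcarbamoyl group, on the same nitrogen would divide the step between them. From the compounds shown here alone, how far the step depends on the remainder of compound 4 is also open, as is whether a smaller group such as acetyl on this nitrogen would keep any of it.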